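A few compounds are considered here, and "the series" means these few. Any claim that something is new, unique, unknown or untested is made for them only; others in the source may bear on it.

Measured compounds:
compound 1 `COC(=O)c1ccc(NCc2cncn2Cc2cccc(C#N)c2)cc1-c1ccccc1` — > 10000 nM in a toxicity assay on NIH3T3 cells (Mus musculus) for cytotoxicity, read by resazurin assay (on this read-out lower numbers stand for an effect already at smaller amounts and higher numbers for an effect only at larger amounts of compound), a limit of the assay
compound 2 `COC(=O)c1ccc(NCc2cncn2Cc2ccc(Br)cc2)cc1-c1ccccc1` — > 10000 nM in this assay, a limit of the assay
compound 3 `COC(=O)c1ccc(NCc2cncn2Cc2ccccc2C)cc1-c1ccccc1` — 10000 nM in this assay

Among the measured compounds shown here, compound 3 stands as the only value that is a number; the other two are limits, as the limit of > 10000 nM in this assay, at which 2 of the 3 values shown sit, shows. Compound 4 `COC(=O)c1ccc(NCc2cncn2Cc2cccc(N)c2)cc1-c1ccccc1` is not yet measured in this assay. The change is 3-aminophenyl in place of 2-methylphenyl on a saturated chain carbon bound to an aromatic nitrogen.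

The steps measured so far all end at compound 3 or run between the two limits: a number no higher from compound 1 to compound 3 (the limit leaves the size open), a number no higher from compound 2 to compound 3 (the limit leaves the size open) and a step that the two limits leave unreadable from compound 1 to compound 2. None of them can be read as a size, and none involves the 3-aminophenyl group. The three values shown all sit at or at the edge of the same level, so no step beyond the scatter is expected from compound 3 to compound 4 in this assay; the expected step is no change at the digits printed from compound 3 to compound 4 (within the scatter). For compound 4 the estimate in this assay is 10000 nM, with a range from 5000 nM to 20000 nM, and a good chance that only a limit is reported.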

Compound 4, half-maximal effective concentration: > 10000 nM
Compound 4 gave a limit, no number; the forecaster's own chance of this, stated with the estimate: 60%; the middle value lies on the limit itself.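

In this assay, 3-aminophenyl in place of 2-methylphenyl on a saturated chain carbon bound to an aromatic nitrogen gives a number no lower from compound 3 to compound 4 (the limit leaves the size open). The hydrogen-bond donor that enters with 3-aminophenyl therefore brings no lower number at this position, and the steps linking compound 4 with compound 1 and compound 2 cannot be read. The series now sits mostly at one edge of the assay range: the limit of > 10000 nM in this assay, at which 3 of the 4 values shown sit.

Going by these compounds, how far compound 1, compound 2 and compound 4 lie past that limit stays unknown, so the size of any gap to compound 3 stays open. Also open, on these data alone, is whether a carboxylic acid in place of the methyl ester, or a longer chain in place of the benzyl link, would give a number in this assay.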